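The compounds below may be only part of what the source reports. "The series", "measured", "known", "first", "only" and "open" are said of these compounds alone.

Series notes, orexin receptor type 2 binding

Measured so far:
- compound 1 `Cc1ccc(-n2nccn2)c(C(=O)N2C[C@H](C#Cc3cnccc3O)CC[C@H]2C)c1` gives 7.5 nM in an assay on cells for binding affinity to Orexin receptor type 2 (Homo sapiens), read by radioligand binding; a higher number here means a weaker inhibitor, a lower number a stronger inhibitor
- compound 2 `Cc1ccc(-n2nccn2)c(C(=O)N2C[C@H](C#Cc3ccc(F)cn3)CC[C@H]2C)c1` gives 1.1 nM in this assay

Among the measured compounds shown here, compound 2 holds the lowest number of the two measured in this assay; its nearest neighbour is compound 1, and the only measured step, a 6.8-fold lower number from compound 1 to compound 2 (0.83 log units; beyond the scatter), concerns the aryl group on the triple-bonded carbon, not the linker itself.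

Compound 3 `Cc1ccc(-n2nccn2)c(C(=O)N2C[C@H](/C=C\c3ccc(F)cn3)CC[C@H]2C)c1` is not yet measured. It differs from compound 2 in one place: 2-(5-fluoropyridin-2-yl)ethenyl in place of 2-(5-fluoropyridin-2-yl)ethynyl on a saturated ring carbon. The aryl group and the shared core are the same as in compound 2; only the two-carbon linker between the saturated ring carbon and the pyridine changes from a triple bond to a double bond.

For the measured compounds named here, no measured step bears on this change. The step from compound 1 to compound 2 tells only how the aryl group moves the number when the ethynyl linker is kept. For compound 3 the expected result in this assay is therefore uncertain, with a small loss considered somewhat more likely than a gain, as a 2.3-fold higher number from compound 2 to compound 3 (0.36 log units; beyond the scatter). Compound 3 is estimated at 2.5 nM, with a range from 0.6 nM to 12 nM.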

Compound 3, inhibition constant: 28 nM
Compound 3: the middle estimate sits 11-fold (1.05 log units) below what was measured; the whole stated range lies below it.
By their numbers in this assay, from the lowest: compound 2; then compound 1; then compound 3.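

Changing only the two-carbon linker on the saturated ring carbon, with the 5-fluoropyridin-2-yl group and the shared core kept, gives in this assay a 25-fold higher number from compound 2 to compound 3 (1.41 log units; beyond the scatter), so at this position, two ring bonds from the ring nitrogen, the ethenyl linker does not stand in for the ethynyl linker. Among the compounds shown here, this linker step is larger than the only aryl step available, a 6.8-fold lower number from compound 1 to compound 2 (0.83 log units; beyond the scatter), and the 5-fluoropyridin-2-yl group does not keep its advantage once the linker changes, since the comparison with the ethynyl compound bearing 4-hydroxypyridin-3-yl gives a 3.7-fold higher number from compound 1 to compound 3 (0.57 log units; beyond the scatter). No supporting evidence is available to explain why the double bond carries the higher number.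

The compounds shown leave open whether a fully saturated ethyl linker, or a one-carbon methylene linker, would sit nearer to compound 2 or to compound 3 in this assay. They also leave open whether the linker step has a similar size with other aryl groups, such as 4-hydroxypyridin-3-yl or an unsubstituted phenyl ring, since only the 5-fluoropyridin-2-yl group is seen on both linkers.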